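From tert-Butyl to Pentyl on the Amide Nitrogen

The compounds below may be only part of what the source reports. "The series", "measured", "known", "first", "only" and "open" are said of these compounds alone.

Three compounds sharing one core differ only at the amide. Compound 1 `COc1cc2c(cc1OC)C(CC(N)=O)CC2` gives 31.3% in a functional assay on the whole organism (strain Wistar) for inhibition, with Rattus norvegicus as the target, read by paw edema, with stated times of 60 min and 4 h, at a dose of 100 mg/kg by the oral route; a lower number here means less inhibition, a higher number more inhibition at the dose given (going by the name of the read-out); compound 2 `COc1cc2c(cc1OC)C(CC(=O)N(C)C)CC2` gives 35.9%; compound 3 `COc1cc2c(cc1OC)C(CC(=O)NC(C)(C)C)CC2` gives 32.8%. Compound 3 stands second highest of the three, yet every step among them lies within the scatter: a number 4.6 percentage points higher from compound 1 to compound 2 (within the scatter), a number 1.5 percentage points higher from compound 1 to compound 3 (within the scatter), a number 3.1 percentage points lower from compound 2 to compound 3 (within the scatter). Compound 4 `CCCCCNC(=O)CC1CCc2cc(OC)c(OC)cc21` differs from compound 3 by pentyl in place of tert-butyl on an amide-type nitrogen. Among the compounds with values here, the steps that bear on this change are a number 1.5 percentage points higher from compound 1 to compound 3 (within the scatter) and a number 3.1 percentage points lower from compound 2 to compound 3 (within the scatter), both within the scatter, so no movement beyond the scatter is expected in this assay. The step from compound 3 to compound 4 is expected to be a number 0.2 percentage points higher from compound 3 to compound 4 (within the scatter). Compound 4 is therefore estimated at 33%, with a range from 24% to 42%.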

Compound 4, a percentage reported as inhibition, in the whole organism at one dose (the size of the read-out at that dose, not a potency): 40.6%
Beside the measured number, compound 4's estimate is 7.6 percentage points below it, and the stated range covers the measured number.
By their numbers in this assay, from the lowest: compounds 1, 3, 2 and 4 (each within the scatter of the next).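

With pentyl in place of tert-butyl on the amide-type nitrogen, this assay shows a number 7.8 percentage points higher from compound 3 to compound 4 (within the scatter) and with pentylamino in place of dimethylamino it shows a number 4.7 percentage points higher from compound 2 to compound 4 (within the scatter) while pentyl in place of hydrogen shows a number 9.3 percentage points higher from compound 1 to compound 4 (within the scatter) as well. Within the data shown here, these are larger steps than any seen among the earlier compounds, yet each stays within the scatter, so pentyl cannot be told apart from the other three amide groups at this position. From the compounds shown here alone, whether a longer chain such as octyl, or a chain ending in an amine or a carboxylic acid, would move the number beyond the scatter stays open. No evidence given here accounts for this result.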